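Swapping fluorine for chlorine on the pyridine ring

The source may hold more compounds than are shown below. What is called first, only, known or untested is meant among the compounds shown, and "the series" means these compounds.

Compound 2, `COc1ccccc1S(=O)(=O)/C=C/c1ncccc1F`, is measured in an ADME assay on BV-2 cells (Mus musculus) for cytotoxicity, with a stated time of 24 h, tested at 10 uM (on this read-out higher numbers stand for a weaker effect at the one concentration tested and lower numbers for a stronger effect), and gives 100%. Within the data shown here, its only measured neighbour is compound 1, `COc1ccccc1S(=O)(=O)/C=C/c1ccccn1`, which in this assay gives 100%. Compound 2 therefore stands level with compound 1 on the numbers shown. Among the measured compounds shown here, the one step already seen, no change at the digits printed from compound 1 to compound 2 (within the scatter), shows that adding a fluoro group at this position left the read-out unchanged within the scatter.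

Compound 3, `COc1ccccc1S(=O)(=O)/C=C/c1ncccc1Cl`, differs from compound 2 in a single place: chloro in place of fluoro on an aromatic carbon. For the measured compounds named here, no measured step covers a fluoro-to-chloro exchange, so the only guidance is that the neighbouring step from compound 1 to compound 2 was flat. On that basis the expected step in this assay, no change at the digits printed from compound 2 to compound 3 (within the scatter), is none beyond the scatter. Compound 3 is therefore estimated to give 100%, with a likely range from 88% to 108%.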

Compound 3, a percentage reported as activity, at one concentration (the size of the read-out at that concentration, not a potency): 100%
For compound 3 middle estimate and measured number coincide at the digits printed; the range from low to high includes it.
By their numbers in this assay, from the lowest: compounds 1, 2 and 3 (each within the scatter of the next).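

Chloro in place of fluoro on this aromatic carbon, ortho to a large group, gives in this assay no change at the digits printed from compound 2 to compound 3 (within the scatter), and chloro in place of hydrogen gives no change at the digits printed from compound 1 to compound 3 (within the scatter) in the same test. The position has now carried hydrogen, fluoro and chloro with the read-out level across all three, so the flat result seen with fluoro also holds for a second halogen. Nothing measured here bears on why the read-out stays level.

Going by these compounds, whether a group of a different kind on this carbon, such as an amine, a carboxylic acid or a longer chain, would also leave the read-out level remains open. Also open, on these data alone, is whether these three compounds would stay level at concentrations other than the one tested.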